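This account rests on a few compounds, and the source may have more. Where it says the series, first, only, none or still open, it means among the compounds named here.

Compound 1 `CC(=O)/C(=N\c1ccc(Cl)cc1)NNc1ccccc1C` gives 1830 nM in an assay on isolated protein for binding affinity to corticotropin-releasing factor receptor 1 (Homo sapiens) (on this read-out higher numbers stand for weaker inhibition and lower numbers for stronger inhibition), and compound 2 `CC(=O)/C(=N\c1cccc(C)c1)NNc1ccccc1C` gives 526 nM in this assay. The two differ by 3-methylphenyl in place of 4-chlorophenyl on a double-bonded nitrogen, and the step is a 3.5-fold lower number from compound 1 to compound 2 (0.54 log units; beyond the scatter). Compound 3 `CC(=O)/C(=N\c1ccc(Cl)cc1)NNc1ccccc1Cl` carries a different core: chloro in place of methyl on an aromatic carbon. The step is a 2.1-fold higher number from compound 1 to compound 3 (0.33 log units; beyond the scatter), and in this assay compound 3 gives 3870 nM, the highest of the three numbers. Compound 4 `CC(=O)/C(=N\c1cccc(C)c1)NNc1ccccc1Cl` has not yet been measured in this assay. It differs from compound 3 by 3-methylphenyl in place of 4-chlorophenyl on a double-bonded nitrogen, the same change as between compound 1 and compound 2, now made on the core of compound 3. For the measured compounds named here, for compound 4 the expected step is a 3.5-fold lower number from compound 3 to compound 4 (0.55 log units; beyond the scatter), which rests on the single earlier step of a 3.5-fold lower number from compound 1 to compound 2 (0.54 log units; beyond the scatter). Compound 4 is thus expected to give about 1100 nM, most likely between 500 nM and 2500 nM.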

Compound 4, inhibition constant: 115 nM
Compound 4: the middle estimate sits 9.6-fold (0.98 log units) above what was measured; measured number outside the range, below it.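

On the core of compound 3, the change to 3-methylphenyl in this assay gives a 34-fold lower number from compound 3 to compound 4 (1.53 log units; beyond the scatter), so the direction seen on the core of compound 1 carries over but the size does not: the same change on two cores in this assay, a 3.5-fold lower number (0.54 log units; beyond the scatter) from compound 1 to compound 2 and a 34-fold lower number (1.53 log units; beyond the scatter) from compound 3 to compound 4, 9.7-fold (0.99 log units) apart, beyond the scatter of two such steps. Read the other way, chloro in place of methyl on an aromatic carbon now gives a 4.6-fold lower number from compound 2 to compound 4 (0.66 log units; beyond the scatter), the opposite direction to the earlier step: the same change on two cores in this assay, a 2.1-fold higher number (0.33 log units; beyond the scatter) from compound 1 to compound 3 and a 4.6-fold lower number (0.66 log units; beyond the scatter) from compound 2 to compound 4, 9.7-fold (0.99 log units) apart, beyond the scatter of two such steps. The two changes therefore do not add up independently in these four compounds, but the data do not show why, or whether other cores would behave the same way.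

As far as these compounds go, it stays open whether a step this large would also appear with a methoxyphenyl group on the double-bonded nitrogen, or with bromo in place of chloro on the aromatic carbon.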